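The compounds below may be only part of what the source reports. "The series", "measured", "known", "first", "only" and "open" are said of these compounds alone.

Measured compounds:
compound 1, `CCOC(=O)c1ccc2[nH]c(-c3ccc(Cl)cc3)c(Oc3ccc(Cl)cc3)c2c1`: 35000 nM
compound 2, `CCOC(=O)C1CCN(C(=S)Sc2c(-c3ccc(Br)cc3)[nH]c3ccc(C)cc23)CC1`: 68000 nM

Both compounds were tested in a functional assay on U-373MG ATCC cells (Homo sapiens) for inhibition, read by MTT assay, with a stated time of 72 h; a higher number here means a weaker inhibitor of growth, a lower number a stronger inhibitor of growth. In this assay compound 1 gives 35000 nM, and compound 2 gives 68000 nM. Compound 2 thus carries the higher of the two numbers, but the gap to compound 1 is within the usual scatter of such measurements, so the two cannot be ranked against each other on these data alone.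

The next compound, compound 3, `CCOC(=O)C1CCN(C(=S)Sc2c(-c3ccc(Br)cc3)[nH]c3ccccc23)CC1`, has not yet been measured in this assay. It differs from compound 2 in one place: hydrogen in place of methyl on an aromatic carbon. Going by the values given here, no pair of measured compounds differing in this single way is available, so there is no direct reading of how large such a step tends to be here.

For this reason the writer expects the step from compound 2 to compound 3 to be small, a 1.0-fold lower number from compound 2 to compound 3 (0.02 log units; within the scatter), and not beyond the scatter in either direction. Compound 3 is accordingly estimated at 65000 nM in this assay, with a plausible range from 25000 nM to 170000 nM.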

Compound 3, concentration for 50% growth inhibition: 35000 nM
Estimate against measurement, compound 3: 1.9-fold (0.27 log units) above; measured number inside the range.
By their numbers in this assay, from the lowest: compounds 1, 3 and 2 (each within the scatter of the next).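

In this assay, putting hydrogen in place of methyl on an aromatic carbon, at the position meta to a fused ring and para to a fused ring, gives a 1.9-fold lower number from compound 2 to compound 3 (0.29 log units; within the scatter), the first direct reading of this change among the compounds shown. On this pair, therefore, the methyl at this position can go without a shift that stands clear of the scatter, and compound 2 and compound 3 cannot be ranked against each other. No measurement is at hand that would explain this step, so nothing can be said about what lies behind it.

The compounds shown leave open whether a different group at this same aromatic carbon, such as a methoxy group, an amine or a carboxylic acid, would move the number beyond the scatter, since methyl and hydrogen are the only two seen here. They also leave open how the number would respond elsewhere on the molecule, for instance if a carboxylic acid or an amide stood in place of the ethyl ester.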